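Swapping one group on compound 2

The source may report more compounds than this note shows. Statements on the series, on what has been measured and on what is new or still open speak of the compounds shown alone.

Among the measured compounds shown here, in a functional assay on HCT-116 cells (Homo sapiens) for cytotoxicity, read by MTT assay, with a stated time of 72 h (a lower number here means a stronger inhibitor, a higher number a weaker inhibitor), compound 2 (`O=C1c2c[n+]([O-])c3ccccc3c2C(=O)c2c1c1ccccc1n2Cc1cn([C@@H]2C[C@H](O)[C@@H](CO)O2)nn1`) gives 50 nM and holds the lowest of the three numbers so far. Compound 1 (`CN(C)CCCCCn1c2c(c3ccccc31)C(=O)c1c[n+]([O-])c3ccccc3c1C2=O`) gives 470 nM by comparison, and compound 3 (`CCCCN1CCN(CCCCn2c3c(c4ccccc42)C(=O)c2c[n+]([O-])c4ccccc4c2C3=O)CC1`) gives 1920 nM at the top of the set. Compound 4 (`CC1(C)O[C@@H](CO)[C@H](Cn2cc(Cn3c4c(c5ccccc53)C(=O)c3c[n+]([O-])c5ccccc5c3C4=O)nn2)O1`) keeps the core of compound 2 and changes one group on an aromatic nitrogen of a five-membered aromatic ring with 3 nitrogen ((5-(hydroxymethyl)-2,2-dimethyl-1,3-dioxolan-4-yl)methyl in place of 4-hydroxy-5-(hydroxymethyl)oxolan-2-yl on an aromatic nitrogen) while the rest stays the same. For the measured compounds named here, the only measured step that bears on this is a 4.1-fold higher number from compound 1 to compound 3 (0.61 log units; beyond the scatter) when 4-butylpiperazin-1-yl takes the place of (dimethylamino)methyl on a saturated chain carbon. It shows that exchanging a single group, with the core untouched, can shift the number by a modest amount, though the groups there are quite different. Compound 2 also sits at the low end, so a modest rise seems likelier than a further fall. The expected change is a 3.0-fold higher number from compound 2 to compound 4 (0.48 log units; beyond the scatter) by this estimate. Compound 4 is estimated at 150 nM with a likely range from 40 nM to 550 nM for this measurement.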

Compound 4, half-maximal inhibitory concentration: 130 nM
Estimate against measurement, compound 4: 1.2-fold (0.06 log units) above, within the range that was stated.
By their numbers in this assay, from the lowest: compound 2; then compound 4; then compound 1; then compound 3.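

Among the compounds shown here, on the aromatic nitrogen of the five-membered aromatic ring with 3 nitrogen, this is the first measured change, and in this assay it gives a 2.6-fold higher number from compound 2 to compound 4 (0.41 log units; beyond the scatter). The position therefore accepts a different ring and a larger group with only a modest shift, although several things change together: 10 heavy atoms replace 8, 1 hydrogen-bond donor replaces 2, and 2 defined stereocentres replace 3, so the step cannot be assigned to any one of these differences. Nothing measured here explains the rise.

As far as these compounds go, it remains open how a simple open chain ending in an amine or a carboxylic acid would behave on this nitrogen. A diol made by removing the 2,2-dimethyl bridge from the entering group would help show whether the intact ring matters.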